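The compounds below may be only part of what the source reports. "The series", "measured", "known", "first", "only" and "open" are said of these compounds alone.

The three measured compounds share one core and differ only in the group on a saturated ring carbon. Compound 1 `Cc1ccccc1Cc1ccc(N2C[C@@H](C)C[C@H]2CC(=O)O)cc1` gives 140 nM in a functional assay on cells for agonist activity at Free fatty acid receptor 1 (Homo sapiens), read by FLIPR and calcium flux, with a stated time of 100 s; a higher number here means that more compound is needed for the effect, a lower number that less compound is needed. Compound 2 `Cc1ccccc1Cc1ccc(N2C[C@@H](C(F)(F)F)C[C@H]2CC(=O)O)cc1` gives 67 nM in this assay, and this stands lowest of the two numbers shown, with compound 1 nearest. Compound 3 `Cc1ccccc1Cc1ccc(N2C[C@@H](c3ccccc3)C[C@H]2CC(=O)O)cc1` reaches only a limit in this assay, reported as > 17000 nM. This limit is the limit of > 17000 nM in this assay, at which 1 of the 3 values shown sits. The step of a 2.1-fold lower number from compound 1 to compound 2 (0.32 log units; beyond the scatter) is modest, whereas an at least 120-fold higher number from compound 1 to compound 3 (2.08 log units; beyond the scatter) and an at least 250-fold higher number from compound 2 to compound 3 (2.40 log units; beyond the scatter) are large.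

Compound 4 `Cc1cccc(Oc2ccc(N3C[C@@H](C(F)(F)F)C[C@H]3CC(=O)O)cc2)c1C` differs from compound 2 at a different place: 2,3-dimethylphenoxy in place of 2-methylbenzyl on an aromatic carbon. Among the compounds with values here, none of the measured steps touches this place; all three concern the group on the saturated ring carbon, so no measured step bears directly on this change. The trifluoromethyl on the saturated ring carbon, which in compound 2 accompanies the lowest number shown, is retained in compound 4. With nothing measured at the changed place, a step beyond the scatter is not expected in either direction. The number expected for compound 4 in this assay is 100 nM, with a range from 25 nM to 400 nM. The expected step is therefore a 1.5-fold higher number from compound 2 to compound 4 (0.17 log units; within the scatter), within the scatter.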

Compound 4, half-maximal effective concentration: 110 nM
Compound 4: the middle estimate sits 1.1-fold (0.04 log units) below what was measured; the range from low to high includes it.
By their numbers in this assay, from the lowest: compounds 2, 4 and 1 (each within the scatter of the next, the first and the last beyond it). At a limit, above all of these: compound 3.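

In this assay, the exchange of 2-methylbenzyl for 2,3-dimethylphenoxy gives a 1.6-fold higher number from compound 2 to compound 4 (0.22 log units; within the scatter), the first step shown at the aromatic carbon para to a large group, as all earlier steps concerned the saturated ring carbon. The step shows that, with trifluoromethyl kept on the saturated ring carbon, this place accepts a group with an oxygen, a hydrogen-bond acceptor and one more heavy atom without a change beyond the scatter, although this single step cannot separate the contribution of the oxygen from that of the second methyl on the ring. Nothing among the data shown explains why the two groups give numbers within the scatter of each other.

The compounds shown leave open whether 2,3-dimethylphenoxy would give a similar result with methyl rather than trifluoromethyl on the saturated ring carbon, and whether a plain phenoxy or 2-methylphenoxy group would behave like it at the same place. They also leave open how this place would respond to a group carrying chlorine or a nitrile on the outer aromatic ring, or to an amine or amide linking the two aromatic rings.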